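The source may report more compounds than this note shows. Statements on the series, on what has been measured and on what is new or still open speak of the compounds shown alone.

The measured compounds are:

compound 1 `Nc1cc(N)c2nc(-c3ccccc3)c(Oc3ccc(Cl)c(Cl)c3)nc2c1`, 6030 nM
compound 2 `COc1ccc(CNc2nc3cc(N)cc(N)c3nc2-c2ccccc2)cc1OC`, 19100 nM
compound 3 `COc1cc(CNc2nc3cc(N)cc(N)c3nc2-c2ccccc2)cc(OC)c1OC`, 7410 nM

All three were tested in a functional assay on RXF 393 cells (Homo sapiens) for inhibition, read by sulforhodamine B assay, with a stated time of 48 h; a higher number here means a weaker inhibitor of growth, a lower number a stronger inhibitor of growth. Among them compound 1 gives the lowest number, but compound 3 sits within the scatter of it, so no order can be drawn between those two; compound 2 lies further off, beyond the scatter. For the measured compounds named here, the only step between compounds that differ in one place is a 2.6-fold lower number from compound 2 to compound 3 (0.41 log units; beyond the scatter), a modest change brought by a methoxy on an aromatic carbon, and it does not touch the part of the molecule that is altered below.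

Compound 4 `Nc1cc(N)c2nc(-c3ccccc3)c(Sc3ccc(Cl)c(Cl)c3)nc2c1` differs from compound 1 by (3,4-dichlorophenyl)sulfanyl in place of 3,4-dichlorophenoxy on an aromatic carbon. Going by the values given here, no measured pair in this set exchanges the linking atom of a 3,4-dichlorophenyl group in this way, so nothing here speaks for a shift in either direction. The two side chains keep the same count of heavy atoms, the same ring and the same donor and acceptor tally. The expectation is therefore that this assay returns a number close to that of compound 1, with no step beyond the scatter. The estimate thus amounts to a 1.0-fold lower number from compound 1 to compound 4 (0.00 log units; within the scatter). Compound 4 is expected to give about 6000 nM, in the range 2500 nM to 15000 nM.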

Compound 4, concentration for 50% growth inhibition: 12300 nM
Compound 4: middle estimate off by 2.1-fold (0.31 log units), on the low side; the range from low to high includes it.
By their numbers in this assay, from the lowest: compounds 1, 3, 4 and 2 (each within the scatter of the next, the first and the last beyond it).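

In this assay the linking atom at this position proves not to be silent: (3,4-dichlorophenyl)sulfanyl in place of 3,4-dichlorophenoxy gives a 2.0-fold higher number from compound 1 to compound 4 (0.31 log units; beyond the scatter) and so a modest step. This is the only step shown at this aromatic carbon, next to the ring nitrogen and ortho to a phenyl group, and it shows that the number responds to the exchange of oxygen for sulfur even though the two side chains match in heavy atoms, ring and donor and acceptor tally. Nothing at hand accounts for the direction of this step.

The compounds shown leave open how this position would read with a secondary amine or a methylene as the link, or with the sulfur carried as a sulfone. They also leave open whether the same exchange would give a step of this direction and size with another group on the phenyl ring, such as a methoxy or a trifluoromethyl in place of the two chlorines.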